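Compound 1 to compound 4: exchanging the methoxycarbonyl group

A few compounds are considered here, and "the series" means these few. Any claim that something is new, unique, unknown or untested is made for them only; others in the source may bear on it.

Values measured in a functional assay on CCRF-CEM cells (Homo sapiens) for cytotoxicity, in the presence of a further agent that is not named here (a higher number here means a weaker inhibitor, a lower number a stronger inhibitor), are as follows.
- Compound 1 (`COC(=O)c1ccc(CN(CCCc2c(N)nc(N)nc2O)c2cc(F)cc(F)c2[N+](=O)[O-])cc1`) gives > 100000 nM (a limit)
- Compound 2 (`Nc1nc(N)c(CCCN(Cc2ccc(NC(CCC(=O)O)C(=O)O)cc2)c2cc(F)c([N+](=O)[O-])cc2[N+](=O)[O-])c(O)n1`) gives 43000 nM (a measured number)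
- Compound 3 (`Nc1nc(N)c(CCCNc2cc(F)cc(F)c2[N+](=O)[O-])c(O)n1`) gives 94000 nM (a measured number)

Compound 1 stands at a limit and has no measured number (the limit of > 100000 nM in this assay, at which 1 of the 3 values shown sits). Compound 4 (`Nc1nc(N)c(CCCN(Cc2ccc(NC(CCC(=O)O)C(=O)O)cc2)c2cc(F)cc(F)c2[N+](=O)[O-])c(O)n1`) differs from it by one exchange, (1,3-dicarboxypropyl)amino in place of methoxycarbonyl on an aromatic carbon. Within the data shown here, the one measured step (an at least 1.0-fold lower number from compound 1 to compound 3 (0.02 log units; that floor lies within the scatter)) puts hydrogen in place of 4-(methoxycarbonyl)benzyl, so it does not isolate this exchange. Compound 4 shares (1,3-dicarboxypropyl)amino with compound 2, although the two differ elsewhere. The closest guide is therefore compound 2 (43000 nM), and a modest move to a lower number is expected in this assay. The expected change is an at least 2.5-fold lower number from compound 1 to compound 4 (0.39 log units; beyond the scatter) and remains uncertain. For compound 4 the estimated value is 40000 nM with an expected range of 10000 nM to 120000 nM (a wide range).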

Compound 4, half-maximal inhibitory concentration: > 100000 nM
Compound 4: a limit, no number (the forecaster's own chance of this, stated with the estimate: 20%); middle value at least 2.5-fold (0.39 log units) away from the limit.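

In this assay compound 4 gives > 100000 nM, which is a limit and not a number; compound 1 also stands only at a limit, so the step between compound 1 and compound 4 cannot be read: the limit of > 100000 nM in this assay, at which 2 of the 4 values shown sit.

The compounds shown leave open whether (1,3-dicarboxypropyl)amino in place of methoxycarbonyl changes the number in this assay at all.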